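Pentafluoroethyl in Place of the Sulfur-Bearing Group, on Compound 4

The source may report more compounds than this note shows. Statements on the series, on what has been measured and on what is new or still open speak of the compounds shown alone.

Compound 1 `CC(O)(COc1ccc(S(F)(F)(F)(F)F)cc1)C(=O)Nc1cc(C(F)(F)F)cc(C(F)(F)F)c1`: 6500 nM
Compound 2 `CC(O)(COc1cccc(S(F)(F)(F)(F)F)c1)C(=O)Nc1cc(C(F)(F)F)cc(C(F)(F)F)c1`: 5700 nM
Compound 3 `CC(O)(COc1cccc(C(F)(F)C(F)(F)F)c1)C(=O)Nc1cc(C(F)(F)F)cc(C(F)(F)F)c1`: 8500 nM

Of the compounds shown here, three have been measured in a functional assay on DU-145 cells (Homo sapiens) for antiproliferative activity, read by propidium iodide staining, with a stated time of 96 h; a lower number here means a stronger inhibitor, a higher number a weaker inhibitor. Compound 1 and compound 2 are built from the same atoms joined differently; the difference between the two cores is not broken down here, and their numbers lie within the scatter of each other. Compound 2 and compound 3 differ in one place: a group of 7 heavy atoms (2 carbon, 5 fluorine; no ring) in place of a group of 6 heavy atoms (5 fluorine, 1 sulfur; no ring), on an aromatic carbon. That change gave a 1.5-fold higher number from compound 2 to compound 3 (0.17 log units; within the scatter).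

Compound 4 `CC(O)(COc1ccc(C(F)(F)C(F)(F)F)cc1)C(=O)Nc1cc(C(F)(F)F)cc(C(F)(F)F)c1` is not yet measured. It differs from compound 1 in the same way: a group of 7 heavy atoms (2 carbon, 5 fluorine; no ring) in place of a group of 6 heavy atoms (5 fluorine, 1 sulfur; no ring), on an aromatic carbon. The surroundings are not identical, since in compound 3 the entering group sits meta to a large group while in compound 4 it sits para to a large group, so this is the same kind of change rather than the same change.

Within the data shown here, the step from compound 1 to compound 4 is expected to be about a 1.4-fold higher number from compound 1 to compound 4 (0.14 log units; within the scatter), resting on the step of a 1.5-fold higher number from compound 2 to compound 3 (0.17 log units; within the scatter) seen in the only matched pair available. Compound 4 is therefore estimated at 9000 nM, with a likely range from 4500 nM to 20000 nM.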

Compound 4, half-maximal inhibitory concentration: 6800 nM
The estimate for compound 4 lay 1.3-fold (0.12 log units) above the measured number, within the range that was stated.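

In this assay, putting 1,1,2,2,2-pentafluoroethyl in place of the sulfur-bearing group on the core of compound 1 gave a 1.0-fold higher number from compound 1 to compound 4 (0.02 log units; within the scatter). Set beside the earlier pair, the change reads the same on both cores: the same change on two cores in this assay, a 1.5-fold higher number (0.17 log units; within the scatter) from compound 2 to compound 3 and a 1.0-fold higher number (0.02 log units; within the scatter) from compound 1 to compound 4, 1.4-fold (0.15 log units) apart, within the scatter of two such steps. Among these compounds, this shows that in these two pairs, including the one where the entering group sits para to a large group, the exchange leaves the number within the scatter, but it does not show that the exchange would behave this way on any other core, and two pairs cannot tell a small real effect from scatter.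

The compounds shown leave open whether another group on the same aromatic carbon, such as an amine, a carboxylic acid or a longer fluorinated chain, would move the number beyond the scatter. They also leave open whether the exchange would read the same if a nitrile or chlorine took the place of the two trifluoromethyl groups on the other ring.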